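Moving the fluorine within the benzyl group of compound 2

A few compounds are considered here, and "the series" means these few. Any claim that something is new, unique, unknown or untested is made for them only; others in the source may bear on it.

In a functional assay on the whole organism for antagonist activity, with Mus musculus as the target (on this read-out lower numbers stand for an effect already at smaller amounts and higher numbers for an effect only at larger amounts of compound), compound 2 `COc1cc(N)c(Cl)cc1NC(=O)C1CCN(Cc2ccc(F)cc2)CC1` gives 0.6 mg/kg, the lowest of the two numbers in this series. Compound 1 `COc1cc(N)c(Cl)cc1NC(=O)C1CCN(CC2CCCCC2)CC1` gives 2.9 mg/kg in this assay. Compound 3 `COc1cc(N)c(Cl)cc1NC(=O)C1CCN(Cc2ccc(OCc3ccccc3)cc2)CC1` gives only a limit in this assay, > 4 mg/kg. Two measured steps frame the change: the step of a 4.8-fold lower number from compound 1 to compound 2 (0.68 log units; beyond the scatter) and the step of an at least 6.6-fold higher number from compound 2 to compound 3 (0.82 log units; beyond the scatter), the latter resting on (the limit of > 4 mg/kg in this assay, at which 1 of the 3 values shown sits). Compound 4 `COc1cc(N)c(Cl)cc1NC(=O)C1CCN(Cc2ccccc2F)CC1` differs from compound 2 by 2-fluorophenyl in place of 4-fluorophenyl on a saturated chain carbon bound to an amine nitrogen in a ring. Neither measured step tests this exact change: one swaps a saturated ring for an aromatic one, the other replaces fluoro with benzyloxy. Since compound 4 keeps the same atoms as compound 2, the outcome is expected to stay close, with at most a modest rise in this assay, the estimated step being a 1.7-fold higher number from compound 2 to compound 4 (0.22 log units; within the scatter). Compound 4 is therefore expected to give about 1 mg/kg in this assay, within a range from 0.4 mg/kg to 3 mg/kg.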

Compound 4, dose for half-maximal effect: > 4 mg/kg
Compound 4: no number, only a limit; the forecaster's own chance of this, stated with the estimate: 10%; at least 4.0-fold (0.60 log units) between middle value and limit.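

In this assay, the place of the fluorine on the benzyl group matters, and not only its presence: the same atoms, rejoined as 2-fluorobenzyl, give an at least 6.6-fold higher number from compound 2 to compound 4 (0.82 log units; beyond the scatter), a step resting on a limit. An aromatic ring on this carbon therefore does not by itself give the low number of compound 2, since the 2-fluorophenyl group gives an at least 1.3-fold higher number from compound 1 to compound 4 (0.13 log units; that floor lies within the scatter), a floor that also rests on a limit. Compound 4, like compound 3, carries no number here, only a limit: the limit of > 4 mg/kg in this assay, at which 2 of the 4 values shown sit.

As far as these compounds go, how far compound 4 lies beyond that limit stays open, so the full size of both steps is unknown. Also open, from the compounds shown here alone, is whether chloro or methoxy in place of the fluoro would show the same dependence on where the group sits.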